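The source may report more compounds than this note shows. Statements on the series, on what has been measured and on what is new or still open speak of the compounds shown alone.

Working notes on the series. In a functional assay on RS4-11 cells (Homo sapiens) for inhibition, read by CCK-8 assay, with a stated time of 48 h, tested at 20 uM (on this read-out higher numbers stand for more inhibition of growth at the one concentration tested and lower numbers for less inhibition of growth), compound 2 (`N#C/C(=C\c1ccccc1OS(=O)(=O)c1ccc([N+](=O)[O-])cc1)C(=O)Nc1nnc(Cc2ccc(F)cc2)s1`) gives 55%. This is the lower of the two readings so far and lies beyond the scatter from compound 1 (`N#C/C(=C\c1ccccc1OS(=O)(=O)c1ccccc1[N+](=O)[O-])C(=O)Nc1nnc(Cc2cccc3ccccc23)s1`), which gives 66%. Compound 3 (`N#C/C(=C\c1ccccc1OS(=O)(=O)c1ccccc1[N+](=O)[O-])C(=O)Nc1nnc(Cc2ccc(F)cc2)s1`) has not yet been measured. It carries 2-nitrophenyl in place of 4-nitrophenyl on a sulfonyl sulfur, with the same atoms joined differently: 2-nitrophenyl in place of 4-nitrophenyl on a sulfonyl sulfur. Within the data shown here, no measured pair isolates this change, so its effect in this assay remains open. The expectation of an upward direction rests only on the higher reading of compound 1 at 66%, which is weak support. The expected step of a number 3 percentage points higher from compound 2 to compound 3 (within the scatter) is small, upward and within the scatter. The estimated value for compound 3 is 58%, with an expected range from 45% to 71%.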

Compound 3, percent growth inhibition at one concentration: 61%
The estimate for compound 3 lay 3 percentage points below the measured number; the measured number falls inside the stated range.
By their numbers in this assay, from the lowest: compounds 2, 3 and 1 (each within the scatter of the next, the first and the last beyond it).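

Among these compounds, compound 3 isolates the exchange on the sulfonyl sulfur for the first time: in this assay, 2-nitrophenyl in place of 4-nitrophenyl gives a number 6 percentage points higher from compound 2 to compound 3 (within the scatter), so this rearrangement of the same atoms cannot be told apart from repeat measurement. It also isolates the other end of the molecule, where 4-fluorophenyl in place of naphthalen-1-yl on a saturated chain carbon bound to an aromatic carbon gives a number 5 percentage points lower from compound 1 to compound 3 (within the scatter). Neither single change therefore steps beyond the scatter on its own.

From the compounds shown here alone, whether an amine or a carboxylic acid in place of the nitro group on the phenyl ring held by the sulfonyl sulfur would give a readable step remains open. Nothing available explains either step.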